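Toward a 4,5-difluoro-2-methylphenyl analogue on the shared core

The source may report more compounds than this note shows. Statements on the series, on what has been measured and on what is new or still open speak of the compounds shown alone.

Measured compounds:
Compound 1, `COc1cc(F)ccc1-c1cc2c(cn1)ncn2-c1ccc(OC(F)F)cc1`: 0.21
Compound 2, `FC(F)Oc1ccc(-n2cnc3cnc(-c4ccccc4OC(F)(F)F)cc32)cc1`: "not determined" (no result reported)
Compound 3, `CCc1ccccc1-c1cc2c(cn1)ncn2-c1ccc(OC(F)F)cc1`: "not determined" (no result reported)

The series shares one core and differs in the aryl group carried on an aromatic carbon next to the ring nitrogen. In an ADME assay on S9 fraction from liver (Mus musculus) for metabolic stability, read by LC-MS, using NADPH, with a stated time of 45 min, tested at 3 uM, in the presence of a further agent that is not named here (on this read-out higher numbers stand for higher hepatic extraction and lower numbers for lower hepatic extraction), compound 1 gives 0.21. For compound 2 the result in this assay stands as "not determined" (no result reported). Compound 3 also has no number in this assay, its entry reading "not determined" (no result reported), so compound 3 cannot be placed against compound 1, and one further compound shares this lack of a number.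

Compound 4, `Cc1cc(F)c(F)cc1-c1cc2c(cn1)ncn2-c1ccc(OC(F)F)cc1`, is the next compound to be read in this assay. It differs from compound 3 by 4,5-difluoro-2-methylphenyl in place of 2-ethylphenyl on an aromatic carbon. For the measured compounds named here, with no numerical value for compound 3, no step can be computed, and the only anchor in this assay is compound 1. Compound 4 is expected to fall near that anchor, with a moderate step upward at most, possibly none beyond the usual scatter. The estimated hepatic extraction ratio for compound 4 in this assay is 0.3, within a range from 0.1 to 0.55.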

Compound 4, hepatic extraction ratio: 0.15
Estimate against measurement, compound 4: 0.15 above, and the stated range covers the measured number.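

In this assay, for the compounds shown here, the exchange of 4-fluoro-2-methoxyphenyl for 4,5-difluoro-2-methylphenyl on this aromatic carbon gives a number 0.060 lower from compound 1 to compound 4 (within the scatter) and is the first step that can be read at this position, showing that this change leaves hepatic extraction within the scatter of repeated measurements. The steps involving compound 2 and compound 3 cannot be read, so this single pair carries the whole comparison. No measured evidence bears on why these two aryl groups read alike here.

As far as these compounds go, whether an amine or a carboxylic acid on this aryl group, or a pyridine in place of its benzene ring, would move hepatic extraction beyond the scatter remains open. Every compound shown also keeps the same difluoromethoxy-substituted phenyl group on the shared core, so the effect of changing that group is open too.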